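An Amino Group in Place of Fluoro on the Outer Ring

The compounds below may be only part of what the source reports. "The series", "measured", "known", "first", "only" and "open" are said of these compounds alone.

Of the compounds shown here, three sharing one core have been measured in an assay on isolated protein for inhibition of Rho-associated protein kinase 2 (Homo sapiens), read by scintillation counting, radiometric assay and 33P incorporation, with a stated time of 40 min, in the presence of a further agent that is not named here; on this read-out higher numbers stand for weaker inhibition and lower numbers for stronger inhibition. Compound 2, `O=C(COc1ccc2c(=O)ccoc2c1)Nc1cccc(NC(=O)c2ccc(F)cc2)c1`, gives 54 nM in this assay. Compound 3, `CN(C)c1ccc(S(=O)(=O)Nc2cccc(NC(=O)COc3ccc4c(=O)ccoc4c3)c2)cc1`, gives 263 nM in this assay, a number that lies beyond the usual scatter from that of compound 2. Compound 1, `CN(C)c1ccc(C(=O)Nc2cccc(NC(=O)COc3ccc4c(c3)OCCO4)c2)cc1`, returns only the limit of the assay, > 10000 nM, and so contributes no number. Among the two numbers in hand, compound 2 therefore stands lowest, with compound 3 clearly weaker, while compound 1 sits at the limit of > 10000 nM in this assay, at which 1 of the 3 values shown sits.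

The next compound, compound 4, `Nc1ccc(C(=O)Nc2cccc(NC(=O)COc3ccc4c(=O)ccoc4c3)c2)cc1`, differs from compound 2 in a single place: amino in place of fluoro on an aromatic carbon. Among the measured compounds shown here, no measured pair in this set changes only that group, so the size of the step has to be expected rather than read off. A small movement, likely a modest weakening in this assay, with a fair chance of landing inside the scatter, is what the change suggests. Compound 4 is accordingly expected to give 120 nM in this assay, with a plausible range from 40 nM to 400 nM. This corresponds to an expected step of a 2.2-fold higher number from compound 2 to compound 4 (0.35 log units; beyond the scatter).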

Compound 4, half-maximal inhibitory concentration: 83 nM
Compound 4: middle estimate off by 1.4-fold (0.16 log units), on the high side; measured number inside the range.
By their numbers in this assay, from the lowest: compounds 2 and 4 (each within the scatter of the next); then compound 3. At a limit, above all of these: compound 1.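

Among the compounds shown here, replacing fluoro with amino at this position, on an aromatic carbon para to a large group, gives the first single-place step in this set: in this assay, the change is a 1.5-fold higher number from compound 2 to compound 4 (0.19 log units; within the scatter) for the 4-fluorophenyl to 4-aminophenyl exchange. The two groups are the same size by heavy-atom count, but amino counts as a hydrogen-bond donor and acceptor and fluoro as neither, and this difference does not separate the two compounds in this assay. For the compounds shown here, nothing measured here accounts for that outcome, and the only further information available, a limit reached by a compound outside this pair, has no bearing on it.

On these data alone, whether a methoxy group, a carboxylic acid or an acetylamino group at the same position would also stay within the scatter of compound 2 remains open, as does the effect of moving the amino group elsewhere on the ring. Compound 1 and compound 3 each differ from this pair in more than one place, so no further step can be read from them.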